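The compounds below may be only part of what the source reports. "The series", "measured", "known", "first", "only" and "open" are said of these compounds alone.

Measured in an assay on isolated protein for binding affinity to 5-hydroxytryptamine receptor 6 (Homo sapiens); on this read-out lower numbers stand for stronger inhibition and higher numbers for weaker inhibition:
compound 1, `COc1ccc(S(=O)(=O)Nc2cccc(Br)c2)cc1N1CCNCC1`: 1.26 nM
compound 2, `COc1ccc(S(=O)(=O)Nc2cccc(I)c2)cc1N1CCNCC1`: 0.501 nM
compound 3, `COc1ccc(S(=O)(=O)Nc2cc(Cl)cc(Cl)c2)cc1N1CCNCC1`: 0.631 nM

Compound 3 stands second highest of the three numbers in this assay. The step of a 1.3-fold higher number from compound 2 to compound 3 (0.10 log units; within the scatter) and the step of a 2.0-fold lower number from compound 1 to compound 3 (0.30 log units; within the scatter) both lie within the scatter, so the three measured compounds sit close together and no order among them can be read from these values.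

Compound 4, `COc1ccc(S(=O)(=O)Nc2cc(Br)cc(Br)c2)cc1N1CCNCC1`, is not yet measured. The change from compound 3 is 3,5-dibromophenyl in place of 3,5-dichlorophenyl on a sulfonamide nitrogen, on a sulfonamide nitrogen whose other neighbour is the sulfonyl sulfur. The step that bears most directly on it is a 2.5-fold lower number from compound 1 to compound 2 (0.40 log units; beyond the scatter), where a heavier halogen on the same aromatic carbon gave a modestly lower number, beyond the scatter. The step of a 2.0-fold lower number from compound 1 to compound 3 (0.30 log units; within the scatter) adds only that two chlorines against one bromine stayed within the scatter. On that basis a modest lower number is expected for compound 4 in this assay, a 1.6-fold lower number from compound 3 to compound 4 (0.20 log units; within the scatter). The estimate for compound 4 is 0.4 nM, with a range from 0.18 nM to 0.9 nM.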

Compound 4, inhibition constant: 0.501 nM
Compound 4: the middle estimate sits 1.3-fold (0.10 log units) below what was measured, and the stated range covers the measured number.
By their numbers in this assay, from the lowest: compounds 2, 4, 3 and 1 (each within the scatter of the next, the first and the last beyond it).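

In this assay, among the compounds shown here, the exchange of 3,5-dichlorophenyl for 3,5-dibromophenyl on a sulfonamide nitrogen gives a 1.3-fold lower number from compound 3 to compound 4 (0.10 log units; within the scatter), so swapping both halogens at once stays inside the scatter, a case the earlier compounds did not cover. Bromo in place of hydrogen on an aromatic carbon gives a 2.5-fold lower number from compound 1 to compound 4 (0.40 log units; beyond the scatter), the only new step beyond the scatter, while the exchange of 3-iodophenyl for 3,5-dibromophenyl gives no change at the digits printed from compound 2 to compound 4 (within the scatter). Nothing available here speaks to the reason for these steps.

Going by these compounds, all four compounds carry only halogens on this aromatic ring, so it remains open whether a methoxy group, a nitrile or an amine there would keep the numbers in this range. On these data alone, whether a methyl group on the sulfonamide nitrogen would do so also stays open.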